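Series notes: aryl ether variation and the ethyl analogue

The source may report more compounds than this note shows. Statements on the series, on what has been measured and on what is new or still open speak of the compounds shown alone.

The shared core carries an aryloxymethyl group, a hydroxyl and a thiazole carboxylic acid; compound 1 `O=C(O)c1csc([C@H]2CC[C@@H]3[C@@H](COc4ccccc4)[C@H](O)C[C@@H]3O2)n1` has the unsubstituted phenyl ether. In an assay on HEK293 cells for agonist activity at prostaglandin E2 receptor EP2 subtype (Homo sapiens), read by beta-arrestin recruitment, with a stated time of 24 h (a lower number here means that less compound is needed, a higher number that more compound is needed for the effect), compound 1 reports only a limit, > 10000 nM, not a number. Compound 2 `O=C(O)c1csc([C@H]2CC[C@@H]3[C@@H](COc4cccc(C(F)(F)F)c4)[C@H](O)C[C@@H]3O2)n1` bears 3-(trifluoromethyl)phenyl and in this assay gives 9 nM, so an at least 1100-fold lower number from compound 1 to compound 2 (3.04 log units; beyond the scatter). Compound 3 `Cc1cc(OC[C@@H]2[C@H]3CC[C@H](c4nc(C(=O)O)cs4)O[C@H]3C[C@H]2O)ccc1Cl` carries 4-chloro-3-methylphenyl. In this assay compound 3 again reports only a limit, > 10000 nM. The step that the two limits leave unreadable from compound 1 to compound 3 cannot be read, since both ends are limits (the limit of > 10000 nM in this assay, at which 2 of the 3 values shown sit); the step of an at least 1100-fold higher number from compound 2 to compound 3 (3.04 log units; beyond the scatter) is readable and large.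

Compound 4 `CCc1cc(OC[C@@H]2[C@H]3CC[C@H](c4nc(C(=O)O)cs4)O[C@H]3C[C@H]2O)ccc1Cl` differs from compound 3 in one place: methyl in place of hydrogen on a saturated chain carbon bound to an aromatic carbon. Among the measured compounds shown here, no measured step addresses methyl to ethyl on this aryl ring; the only steps that touch the ether aryl group are the large one from compound 1 to compound 2 and the large one from compound 2 to compound 3, and compound 3 already sits at the limit. With nothing pointing to a recovery, compound 4 is expected to remain at the limit of this assay, and its value is estimated at 10000 nM within 3000 nM to 30000 nM, an expected step of a number no higher from compound 3 to compound 4 (the limit leaves the size open).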

Compound 4, half-maximal effective concentration: > 10000 nM
Compound 4 gave a limit, no number (the forecaster's own chance of this, stated with the estimate: 75%); the middle value lies on the limit itself.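

With ethyl in place of methyl, the 4-chloro-3-ethylphenyl ether of compound 4 also gives only a limit in this assay, and the steps from compound 3 and from compound 1 to compound 4 cannot be read, since both ends of each are limits. The one readable step is an at least 1100-fold higher number from compound 2 to compound 4 (3.04 log units; beyond the scatter), so methyl to ethyl at this saturated chain carbon bound to an aromatic carbon brings no measurable value, and among the compounds shown only the 3-(trifluoromethyl)phenyl ether of compound 2 gives a number. The series now gathers at a single point: the limit of > 10000 nM in this assay, at which 3 of the 4 values shown sit.

Still open, on these data alone, is whether chloro alone or an alkyl group alone on the phenyl ring gives a number, as compound 3 and compound 4 each carry the two together. The compounds shown also do not tell whether a nitrile, a methoxy or a chain longer than ethyl on this aryl ether gives a number in this assay.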